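From Methyl to Fluoro on a Shared Core

This account rests on a few compounds, and the source may have more. Where it says the series, first, only, none or still open, it means among the compounds named here.

Compound 1 `O=C(Nc1cc(-c2nc3ccccc3s2)ccc1Cl)c1cc([N+](=O)[O-])ccc1Cl` gives > 25000 nM as a limit
Compound 2 `Cc1ccc(-c2nc3ccccc3s2)cc1NC(=O)c1cc([N+](=O)[O-])ccc1Cl` gives > 14000 nM as a limit

Both results come from an ADME assay on Raji cells (Homo sapiens) for cytotoxicity, with a stated time of 72 h (on this read-out lower numbers stand for an effect already at smaller amounts and higher numbers for an effect only at larger amounts of compound), and neither is an exact number. Compound 2 has only a limit here (> 14000 nM) and so has no exact place on the scale. Compound 1 also has only a limit (> 25000 nM) and no exact place either. The two limits cannot be ranked against each other.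

The unmeasured compound 3 `O=C(Nc1cc(-c2nc3ccccc3s2)ccc1F)c1cc([N+](=O)[O-])ccc1Cl` differs from compound 2 by a single exchange (fluoro in place of methyl on an aromatic carbon) and keeps everything else. Going by the values given here, the only measured step at this place (a step that the two limits leave unreadable from compound 1 to compound 2) gives no size that could be carried over. With no readable size to build on, no shift in either direction beyond the usual scatter is expected, and another limit is quite likely. The expected step (a step that the limit leaves unreadable from compound 2 to compound 3) is therefore only a rough estimate. Compound 3 is estimated at 20000 nM with 7000 nM to 40000 nM as the expected range.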

Compound 3, half-maximal effective concentration: > 25000 nM
Compound 3 gave a limit, no number; the forecaster's own chance of this, stated with the estimate: 75%; middle value at least 1.2-fold (0.09 log units) from the limit.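

Compound 3 gives only a limit, as do compound 1 and compound 2, so the steps from compound 1 and compound 2 to compound 3 cannot be read. The compounds shown leave open where any of the three would reach its half-maximal effect on the cells, and whether chloro, methyl and fluoro at this place differ at all.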